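Methoxy for chloro on the outer ring of compound 2

The source may report more compounds than this note shows. Statements on the series, on what has been measured and on what is new or still open speak of the compounds shown alone.

Three compounds of the series have a number in a functional assay on M14 cells (Homo sapiens) for inhibition, read by sulforhodamine B assay, with a stated time of 48 h; a lower number here means a stronger inhibitor of growth, a higher number a weaker inhibitor of growth. Compound 1 `N=C(N)c1ccc(-c2ccc(-c3ccc(F)cc3)s2)cc1` gives 1600 nM. Compound 2 `N=C(N)c1ccc(-c2ccc(-c3ccc(Cl)cc3)s2)cc1F`, which carries a fluorine on the ring that bears the amidine and a chloro on the outer ring, gives 179 nM. Compound 3 `COc1cc(OC)cc(-c2ccc(-c3ccc(C(=N)N)c(F)c3)s2)c1`, with two methoxy groups on the outer ring, gives 184 nM. Compound 2 has the lowest number of the three, but the gap to compound 3 is within the scatter, so the two cannot be ordered; only compound 1 stands apart, with a number beyond the scatter above that of compound 2.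

The next compound, compound 4 `COc1ccc(-c2ccc(-c3ccc(C(=N)N)c(F)c3)s2)cc1`, is not yet measured. It differs from compound 2 in one place: methoxy in place of chloro on an aromatic carbon

Among the measured compounds shown here, no step between measured compounds isolates this exchange. The nearest guide is that compound 3, with methoxy groups on the outer ring, sits at 184 nM, close to the chloro-bearing compound 2. The step from compound 2 to compound 4 is therefore expected to be small, a 1.4-fold higher number from compound 2 to compound 4 (0.15 log units; within the scatter), probably not beyond the scatter, with a slight lean toward a higher number. Compound 4 is expected to give about 250 nM, within a range of 100 nM to 700 nM.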

Compound 4, concentration for 50% growth inhibition: 1900 nM
Estimate against measurement, compound 4: 7.6-fold (0.88 log units) below, and the stated range ends below it.
By their numbers in this assay, from the lowest: compounds 2 and 3 (each within the scatter of the next); then compounds 1 and 4 (each within the scatter of the next).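

In this assay, among the compounds shown here, the exchange of chloro for methoxy on the outer ring gives the first step that isolates a single change, and it is large: an 11-fold higher number from compound 2 to compound 4 (1.03 log units; beyond the scatter), beyond the scatter. For the compounds shown here, with the rest of compound 2 held fixed, the aromatic carbon para to a large group is therefore not indifferent to the group it carries, which the earlier compounds, none of them a one-place pair, could not show. No measurement at hand accounts for the size of this step.

A single exchange cannot separate what is gained with methoxy from what is lost with chloro, so the reading at this carbon would need further groups there, such as methyl, hydroxyl or an amine, or plain hydrogen, all on the core of compound 2. It also remains open whether a step of this size would recur on a core without the fluorine on the ring that bears the amidine, since the one pair shown carries that fluorine on both sides.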